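Rat paw edema series: step from compound 2 to compound 4

This account rests on a few compounds, and the source may have more. Where it says the series, first, only, none or still open, it means among the compounds named here.

Measured compounds, read as inhibition of paw edema:
compound 1 `N#CC1=C(NCC(=O)O)N(c2ccccc2)C(=O)N2CCCCC(N3CCCC3)C12`, 67.2%
compound 2 `N#CC1=C(/N=C/c2ccccc2)N(c2ccccc2)C(=O)N2CCCCC(N3CCCC3)C12`, 46.5%
compound 3 `N#Cc1c2n(c(=O)n(-c3ccccc3)c1=N)CCCCC2N1CCCC1`, 84.6%

In a functional assay on the whole organism (strain albino) for inhibition, with Rattus norvegicus as the target, read by paw edema, with a stated time of 1 h, at a dose of 20 mmol/kg by the intraperitoneal route (on this read-out higher numbers stand for more inhibition at the one dose given (going by the name of the read-out) and lower numbers for less inhibition), compound 2 gives 46.5%, the lowest of the three numbers; compound 1 gives 67.2% and compound 3 gives 84.6%, both beyond the scatter above compound 2. Going by the values given here, the step of a number 20.7 percentage points lower from compound 1 to compound 2 (beyond the scatter) is the only measured step that touches the same position, and it shows that exchanging the group on the double-bonded ring carbon moves the read-out by a modest amount.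

Compound 4 `N#CC1=C(NCC(=O)N2CCCCC2)N(c2ccccc2)C(=O)N2CCCCC(N3CCCC3)C12` is not yet measured. The change from compound 2 is a group of 10 heavy atoms (7 carbon, 2 nitrogen, 1 oxygen; one six-membered non-aromatic ring with 1 hetero atom) in place of a group of 8 heavy atoms (7 carbon, 1 nitrogen; one six-membered aromatic ring of carbon only), on a double-bonded ring carbon. The entering group shares the amino-carbonyl-methyl pattern of compound 1, so the step from compound 2 is expected to run in the opposite direction to a number 20.7 percentage points lower from compound 1 to compound 2 (beyond the scatter), back toward the number of compound 1, as a modest rise: a number 13.5 percentage points higher from compound 2 to compound 4 (beyond the scatter) is the expected step. Compound 4 is therefore estimated at 60%, with a range from 46% to 74%.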

Compound 4, a percentage reported as inhibition, in the whole organism at one dose (the size of the read-out at that dose, not a potency): 38%
The estimate for compound 4 lay 22 percentage points above the measured number, outside the stated range (below it).
By their numbers in this assay, from the lowest: compounds 4 and 2 (each within the scatter of the next); then compound 1; then compound 3.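

Piperidin-1-yl in place of hydroxy on a carbonyl carbon gives a number 29.2 percentage points lower from compound 1 to compound 4 (beyond the scatter) in this assay, so this side chain responds to a change at its far end and not only to the exchange of the whole group. The step of a number 8.5 percentage points lower from compound 2 to compound 4 (within the scatter) does not separate (((piperidin-1-yl)carbonyl)methyl)amino from the group it replaces on the double-bonded ring carbon, so the amino-carbonyl-methyl pattern shared with compound 1 does not by itself hold the number of compound 1. Nothing at hand bears on the reason for this result.

The compounds shown leave open how a methyl ester or a dimethylamino group on that carbonyl carbon would read, and so whether the hydroxy itself matters. They also leave open how a longer chain ending in the same carboxylic acid would read.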